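A Fluorine Added Where a Limit Already Stands

The source may hold more compounds than are shown below. What is called first, only, known or untested is meant among the compounds shown, and "the series" means these compounds.

In a functional assay on MGC-803 cells (Homo sapiens) for antiproliferative activity, read by CellTiter-Glo, with a stated time of 72 h (a higher number here means a weaker inhibitor, a lower number a stronger inhibitor), compound 1 `O=C(NO)c1cccc(/C=C/c2ccnc(-c3cc(F)ccc3O)c2)c1` gives 2710 nM.
In this assay compound 2 `O=C(NO)c1cccc(/C=C/c2ccnc(-c3ccccc3O)c2)c1` gives 2810 nM.
In this assay compound 3 `Cc1ccc(-c2cc(/C=C/c3ccc(C(=O)NO)cc3)c(F)cn2)cc1` reaches only a limit of the assay, > 10000 nM, and no number.

Compound 1 and compound 2 share one core, and the change between them is a single atom: fluoro in place of hydrogen on an aromatic carbon. That change made a 1.0-fold lower number from compound 2 to compound 1 (0.02 log units; within the scatter), so the two values stand within the scatter of each other and no order between them can be read.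

Compound 3 has a different core; the difference between the two cores is not broken down here. Its value sits at the limit of > 10000 nM in this assay, at which 1 of the 3 values shown sits, so its true potency is only known to lie beyond that point.

Compound 4 `Cc1ccc(-c2cc(/C=C/c3ccc(C(=O)NO)cc3)c(F)cn2)c(F)c1` is not yet measured. It differs from compound 3 by the same kind of change as compound 1 from compound 2: fluoro in place of hydrogen on an aromatic carbon. The surroundings differ, though: in compound 1 the fluorine is meta to a large group and para to a hydroxy group, while in compound 4 it is ortho to a large group and meta to a methyl group.

Since the earlier fluorine step between compound 2 and compound 1 stayed within the scatter, compound 4 is expected to change little from compound 3, a step that the limit leaves unreadable from compound 3 to compound 4. The estimate for compound 4 in this assay is therefore 12000 nM, most likely again reported only as a limit.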

Compound 4, half-maximal inhibitory concentration: 2510 nM
Compound 4: the middle estimate sits 4.8-fold (0.68 log units) above what was measured, outside the stated range (below it).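

Putting fluoro in place of hydrogen, which turns 4-methylphenyl into 2-fluoro-4-methylphenyl, gave an at least 3.9-fold lower number from compound 3 to compound 4 (0.60 log units; beyond the scatter) in this assay. The same single-atom change therefore did not carry over from one core to the other with the same size, and setting the two steps side by side makes this plain: the same change on two cores in this assay, a 1.0-fold lower number (0.02 log units; within the scatter) from compound 2 to compound 1 and an at least 3.9-fold lower number (0.60 log units; beyond the scatter) from compound 3 to compound 4, at least 3.8-fold (0.58 log units) apart, beyond the scatter of two such steps. From the compounds shown here alone, compound 3 stands at a limit of the assay, > 10000 nM, not at a number, so the full size of its step remains unknown, and two pairs cannot show a general rule for the series.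

The compounds shown leave open whether the core or the place of the fluorine accounts for the gap, as the two fluorines differ in their surroundings as well as in their cores. They also leave open whether fluoro ortho to a large group on the core of compound 1 would act as it does in compound 4, and whether chloro or a methoxy group in that place would match fluoro.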